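The compounds below may be only part of what the source reports. "The series", "measured", "known", "first", "only" and "open" are said of these compounds alone.

Series notes, alpha-ketooxazole inhibitors of fatty-acid amide hydrolase.

Compound 1 `O=C(c1ncc(-c2ccccn2)o1)C1CCc2cc(Oc3ccccc3)ccc2O1` was measured twice in an assay for inhibition of Fatty-acid amide hydrolase 1 (Rattus norvegicus), using a Dixon plot (on this read-out lower numbers stand for stronger inhibition and higher numbers for weaker inhibition), and gives 36 nM; 120 nM (2 entries); the spread between the two entries of compound 1 the several entries of compound 1 in this assay, 36 nM; 120 nM (2 entries) is itself worth keeping in mind when reading the rest. Compound 2 `O=C(c1ncc(I)o1)[C@@H]1COc2cc(Oc3ccccc3)ccc2C1` gives 31 nM in this assay. Compound 3 `O=C(c1ncc(-c2ccccn2)o1)C1COc2cc(OCc3ccccc3)ccc2C1` gives 17 nM in this assay. Among the single numbers, compound 2 stands highest, but its nearest neighbour is compound 3, and the gap between the two is within the scatter, so no order between compound 2 and compound 3 can be read from these values.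

Compound 4 `O=C(c1ncc(-c2ccccn2)o1)[C@@H]1COc2cc(Oc3ccccc3)ccc2C1` has not yet been measured in this assay. It differs from compound 2 in one place: pyridin-2-yl in place of iodo on an aromatic carbon. Going by the values given here, no measured pair isolates this change, so the expectation leans on compound 3, whose pyridin-2-yl analogue gives 17 nM, and on the scatter seen for compound 1. The step expected in this assay is small, toward a lower number, and may not exceed the scatter; the expected step is a 2.1-fold lower number from compound 2 to compound 4 (0.32 log units; beyond the scatter). For compound 4 the estimate is 15 nM, with a range from 4 nM to 60 nM.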

Compound 4, inhibition constant: 27 nM
For compound 4 the middle estimate is 1.8-fold (0.26 log units) below the measured one; measured number inside the range.
By their numbers in this assay, from the lowest: compounds 3, 4 and 2 (each within the scatter of the next).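

Going by these compounds alone, this is the first pair that isolates this change at the carbon next to the ring oxygen. In this assay, pyridin-2-yl in place of iodo gives a 1.1-fold lower number from compound 2 to compound 4 (0.06 log units; within the scatter), so no change can be read from this pair, although a single iodine is replaced by a six-membered aromatic ring carrying a hydrogen-bond acceptor. A step of this size is also small against the repeat spread seen in the series: the several entries of compound 1 in this assay, 36 nM; 120 nM (2 entries)

Going by these compounds, whether a carboxylic acid or an amine on the pyridin-2-yl ring would leave the number equally unmoved remains open. Also open, on these data alone, is whether the same exchange behaves alike on the core of compound 1 or with the benzyloxy group of compound 3.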